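Sulfonyl aryl variation on the shared core, next step

The source may hold more compounds than are shown below. What is called first, only, known or untested is meant among the compounds shown, and "the series" means these compounds.

Three compounds of the series share one core and differ only in the aryl group on the sulfonyl sulfur. In an assay on isolated protein for displacement of a labelled ligand from metabotropic glutamate receptor 5 (Homo sapiens), with a stated time of 60 min, tested at 1 uM (on this read-out higher numbers stand for more inhibition at the one concentration tested (going by the name of the read-out) and lower numbers for less inhibition), compound 1 `CC1CCN(c2c(S(=O)(=O)c3ccc(F)cc3)cnc3ccc(Cl)cc23)CC1` gives 89%. In this assay compound 2 `Cc1ccc(S(=O)(=O)c2cnc3ccc(Cl)cc3c2N2CCC(C)CC2)cc1Cl` gives 81%, and compound 3 `CC1CCN(c2c(S(=O)(=O)c3cc(Cl)cc(Cl)c3)cnc3ccc(Cl)cc23)CC1` gives 88%. Compound 3 thus stands second highest of the three numbers, nearest to compound 1 and furthest from compound 2, with the steps of a number 1 percentage points lower from compound 1 to compound 3 (within the scatter) and a number 7 percentage points higher from compound 2 to compound 3 (within the scatter); the remaining step is a number 8 percentage points lower from compound 1 to compound 2 (within the scatter).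

Compound 4 `COc1ccc(S(=O)(=O)c2cnc3ccc(Cl)cc3c2N2CCC(C)CC2)cc1Cl` is the next member. The change from compound 3 is 3-chloro-4-methoxyphenyl in place of 3,5-dichlorophenyl on a sulfonyl sulfur.

All three measured steps exchange the aryl group on the same sulfonyl sulfur and none of them moves the read-out beyond the scatter. The step from compound 1 to compound 2 is the closest analogue of the change at hand, since 3-chloro-4-methylphenyl shares the chlorine with 3-chloro-4-methoxyphenyl, and it came out within the scatter. Within the data shown here, no measured compound carries a methoxy on this aryl group, so the comparison rests on the three exchanges alone. The expected step in this assay is therefore a number 4 percentage points lower from compound 3 to compound 4 (within the scatter), no change beyond the scatter. Compound 4 is estimated at 84%, with a range from 70% to 95%.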

Compound 4, a percentage reported as inhibition, at one concentration (the size of the read-out at that concentration, not a potency): 46%
For compound 4 the middle estimate is 38 percentage points above the measured one; the measured number lies below the stated range.
By their numbers in this assay, from the lowest: compound 4; then compounds 2, 3 and 1 (each within the scatter of the next).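

Until now, exchanges of the aryl group on the sulfonyl sulfur had produced no step beyond the scatter in this assay, so this position looked indifferent to the choice of aryl group. That no longer holds: 3-chloro-4-methoxyphenyl gives a number 42 percentage points lower from compound 3 to compound 4 (beyond the scatter) against 3,5-dichlorophenyl and a number 43 percentage points lower from compound 1 to compound 4 (beyond the scatter) against 4-fluorophenyl. The cleanest reading is the smallest change in the set, methoxy in place of methyl on an aromatic carbon, which gives a number 35 percentage points lower from compound 2 to compound 4 (beyond the scatter) even though the chlorine stays, so the loss in this aryl series goes with that single exchange. Nothing at hand gives a reason for this loss.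

The compounds shown leave open whether the loss belongs to the methoxy alone or extends to other groups in that place, which 3-chloro-4-ethoxyphenyl or 3-chloro-4-hydroxyphenyl on the same sulfur would test. They also leave open whether the methoxy costs as much without the chlorine, as in 4-methoxyphenyl on the shared core.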